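The source may report more compounds than this note shows. Statements on the series, on what has been measured and on what is new or still open speak of the compounds shown alone.

Working notes on the oxime-bearing hydroxamate series.

Compound 1 `O=C(CCCCCCN1C(=O)/C(=N\O)c2cc(Br)ccc21)NO` in a functional assay on SW-620 cells (Homo sapiens) for antiproliferative activity, read by sulforhodamine B assay, with a stated time of 48 h (a higher number here means a weaker inhibitor, a lower number a stronger inhibitor), gives 290 nM. Compound 2 `Cc1ccc2c(c1)/C(=N/O)C(=O)N2CCCCCCC(=O)NO` in this assay gives 990 nM. Compound 3 `CO/N=C1/C(=O)N(CCCCCCC(=O)NO)c2ccc(Br)cc21` in this assay gives 2320 nM, the highest number of the three measured. The difference between the core of compound 1 and the core of compound 3 is not broken down here.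

The change from compound 1 to compound 2 is methyl in place of bromo on an aromatic carbon
and it made a step of a 3.4-fold higher number from compound 1 to compound 2 (0.53 log units; beyond the scatter).

Compound 4 `CO/N=C1/C(=O)N(CCCCCCC(=O)NO)c2ccc(C)cc21` is not yet measured. It differs from compound 3 by methyl in place of bromo on an aromatic carbon
which is the same change as that made from compound 1 to compound 2, at the same place. On that basis a step of a 3.0-fold higher number from compound 3 to compound 4 (0.48 log units; beyond the scatter) is expected in this assay, roughly the size seen from compound 1 to compound 2. Compound 4 is thus estimated at 7000 nM, with an expected range from 2500 nM to 20000 nM.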

Compound 4, half-maximal inhibitory concentration: 1070 nM
Compound 4: the middle estimate sits 6.5-fold (0.82 log units) above what was measured, outside the stated range (below it).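

On the core of compound 3, methyl in place of bromo gives a 2.2-fold lower number from compound 3 to compound 4 (0.34 log units; beyond the scatter) in this assay. The change therefore does not carry over between these two cores with a fixed size or even a fixed direction: the same change on two cores in this assay, a 3.4-fold higher number (0.53 log units; beyond the scatter) from compound 1 to compound 2 and a 2.2-fold lower number (0.34 log units; beyond the scatter) from compound 3 to compound 4, 7.4-fold (0.87 log units) apart, beyond the scatter of two such steps

This rests on two pairs of compounds only; it shows that the step differs between these two cores, but not why it differs or how the change would behave on any other core.

The compounds shown leave open how other groups at this place on the aromatic ring, such as chloro or methoxy, would behave on each core. From the compounds shown here alone, it also remains open whether a longer chain would alter either step.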